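Swapping propyl for 4-fluorophenyl on the shared core

The source may report more compounds than this note shows. Statements on the series, on what has been measured and on what is new or still open speak of the compounds shown alone.

compound 1 `Cn1ncc2c(-c3ccc(F)cc3)cc(NNC(=O)Nc3cc(Cl)nc(OCCF)c3)nc21`: 29300 nM
compound 2 `CCCc1cc(NNC(=O)Nc2cc(Cl)nc(Cl)c2)nc2c1cnn2C`: 38700 nM

Both values come from a functional assay on SW620/5-FU cells (Homo sapiens) for cytotoxicity, read by MTT assay, with a stated time of 48 h, in the presence of a further agent that is not named here; a higher number here means that more compound is needed for the effect, a lower number that less compound is needed. In this assay compound 2 stands within the usual scatter of compound 1, so the two numbers set no order between them. The next compound to be read is compound 3 `Cn1ncc2c(-c3ccc(F)cc3)cc(NNC(=O)Nc3cc(Cl)nc(Cl)c3)nc21`. It departs from compound 2 at one place: 4-fluorophenyl in place of propyl on an aromatic carbon. This puts 4-fluorophenyl in place of propyl on an aromatic carbon, opposite the ring nitrogen. Among the compounds with values here, no measured pair yet shows this change on its own. The same group is present in compound 1 at 29300 nM, so no step beyond the scatter is expected in this assay, in either direction. The expected change is a 1.3-fold lower number from compound 2 to compound 3 (0.11 log units; within the scatter). The estimated value for compound 3 is 30000 nM, with an expected range from 11000 nM to 80000 nM.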

Compound 3, half-maximal effective concentration: 9150 nM
Estimate against measurement, compound 3: 3.3-fold (0.52 log units) above, outside the stated range (below it).
By their numbers in this assay, from the lowest: compound 3; then compounds 1 and 2 (each within the scatter of the next).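

In this assay, within the data shown here, the swap of propyl for 4-fluorophenyl on the aromatic carbon opposite the ring nitrogen gives a 4.2-fold lower number from compound 2 to compound 3 (0.63 log units; beyond the scatter) as the first reading of this change on its own, and the step lies beyond the scatter. A second single change, chloro in place of 2-fluoroethoxy on an aromatic carbon with 4-fluorophenyl kept, gives a 3.2-fold lower number from compound 1 to compound 3 (0.51 log units; beyond the scatter) and so also ends at compound 3, which has the lowest number of the three. Nothing measured here accounts for either step.

Open, from the compounds shown here alone, is whether the step at this position needs the fluorine of 4-fluorophenyl or would also appear with plain phenyl or a longer chain. Also open, going by these compounds, is how an amine would read in place of the chloro kept in compound 3.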